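Aryl swap on an indolyl-naphthoquinone core and cytotoxicity

The source may report more compounds than this note shows. Statements on the series, on what has been measured and on what is new or still open speak of the compounds shown alone.

Compound 1 `COc1ccccc1C(C1=C(O)C(=O)c2ccccc2C1=O)c1c[nH]c2ccccc12` gives > 200000 nM in a toxicity assay (Homo sapiens) for cytotoxicity, read by MTT assay, with a stated time of 48 h; on this read-out higher numbers stand for weaker inhibition and lower numbers for stronger inhibition; for compound 1 this is a limit of the assay, not a number.
Compound 2 `O=C1C(O)=C(C(c2ccc(F)cc2)c2c[nH]c3ccccc23)C(=O)c2ccccc21` gives 65200 nM in this assay.
Compound 3 `O=C1C(O)=C(C(c2ccc(Cl)cc2)c2c[nH]c3ccccc23)C(=O)c2ccccc21` gives 102000 nM in this assay.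

Compound 3 holds the highest of the two numbers in this assay; its nearest neighbour is compound 2, with a 1.6-fold higher number from compound 2 to compound 3 (0.19 log units; within the scatter). Compound 1 stands apart as a limit (the limit of > 200000 nM in this assay, at which 1 of the 3 values shown sits).

Compound 4 `COc1cccc(C(C2=C(O)C(=O)c3ccccc3C2=O)c2c[nH]c3ccccc23)c1` is not yet measured. It differs from compound 3 in one place: 3-methoxyphenyl in place of 4-chlorophenyl on a saturated chain carbon bound to an aromatic carbon and a double-bonded ring carbon.

Within the data shown here, the steps that bear on this change run the other way, from a methoxyphenyl to a halophenyl: an at least 3.0-fold lower number from compound 1 to compound 2 (0.48 log units; beyond the scatter) and an at least 1.9-fold lower number from compound 1 to compound 3 (0.29 log units; that floor lies within the scatter). Both lower the number from the methoxy-bearing compound 1, the first clearly, the second only to a floor inside the scatter. Compound 4 carries the methoxy group at a different position from compound 1, so the two steps are only a loose guide. The expectation for compound 4 is therefore a rise in this assay, of modest size, possibly even up to a limit: a 1.5-fold higher number from compound 3 to compound 4 (0.17 log units; within the scatter). Compound 4 is estimated at 150000 nM, within a range from 70000 nM to 320000 nM.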

Compound 4, half-maximal inhibitory concentration: 110000 nM
The estimate for compound 4 lay 1.4-fold (0.13 log units) above the measured number, within the range that was stated.
By their numbers in this assay, from the lowest: compounds 2, 3 and 4 (each within the scatter of the next). At a limit, above all of these: compound 1.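

In this assay, the step from the halophenyl compounds to the 3-methoxyphenyl group stays small in both cases, a 1.1-fold higher number from compound 3 to compound 4 (0.03 log units; within the scatter) and a 1.7-fold higher number from compound 2 to compound 4 (0.23 log units; within the scatter), so among these three compounds a methoxyphenyl group at this place reads no differently from a 4-chlorophenyl or 4-fluorophenyl group. Moving from the 2-methoxyphenyl to the 3-methoxyphenyl group gives an at least 1.8-fold lower number from compound 1 to compound 4 (0.25 log units; that floor lies within the scatter), which means that compound 4 returns a number, yet the difference from compound 1 cannot be said to exceed the scatter. Compound 1 remains a limit of the assay, not a number: the limit of > 200000 nM in this assay, at which 1 of the 4 values shown sits.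

The compounds shown leave open how far compound 1 truly lies from the other three, and so whether the place of the methoxy group on the ring matters at all. Among these compounds, they also leave open whether an aryl group carrying an amine or a carboxylic acid at this place would move the number beyond the scatter, which no step among compounds 2, 3 and 4 does.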